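The source may report more compounds than this note shows. Statements on the series, on what has been measured and on what is new or still open speak of the compounds shown alone.

The account follows the step from compound 2 to compound 3 in a small set sharing one core. Compound 2 `COC(=O)c1cc(-c2cccc(NC(=O)c3ccc(/C=C/C(=O)c4ccc(Cl)cc4)cc3)c2)on1` was tested in an ADME assay on Vero cells (Chlorocebus sabaeus) for cytotoxicity, read by MTT assay, with a stated time of 72 h; a lower number here means that less compound is tolerated, a higher number that more compound is tolerated. For compound 2 this assay gives only a limit, > 50 ug/mL. Its measured partner, compound 1 `COC(=O)c1cc(-c2cccc(NC(=O)c3ccc(/C=C/C(=O)c4ccc(CC(C)C)cc4)cc3)c2)on1`, likewise gives only a limit in this assay, > 10 ug/mL. Within the data shown here, the single measured step among them, a step that the two limits leave unreadable from compound 1 to compound 2, offers no readable size, since both the limit of > 10 ug/mL in this assay, at which 1 of the 2 values shown sits, and the limit of > 50 ug/mL in this assay, at which 1 of the 2 values shown sits, are limits rather than numbers. Compound 3 `CCCOc1ccc(C(=O)/C=C/c2ccc(C(=O)Nc3cccc(-c4cc(C(=O)OC)no4)c3)cc2)cc1` differs from compound 2 by propoxy in place of chloro on an aromatic carbon. Among the measured compounds shown here, no measured step speaks to this change, so no shift beyond the scatter in this assay is expected, and the estimated step is a number no higher from compound 2 to compound 3 (the limit leaves the size open). Compound 3 is therefore expected to give about 50 ug/mL in this assay, within a range from 15 ug/mL to 150 ug/mL, and it may well again appear only as a limit.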

Compound 3, half-maximal cytotoxic concentration: > 40 ug/mL
Compound 3 ended at the assay's limit (the forecaster's own chance of this, stated with the estimate: 55%); the middle value does not contradict the limit.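

Compound 3, like compound 1 and compound 2, gives only a limit in this assay, so no step among these three compounds can be read. The compounds shown leave open whether exchanging isobutyl, chloro and propoxy on this aromatic carbon changes the read-out of this assay at all.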